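This account rests on a few compounds, and the source may have more. Where it says the series, first, only, none or still open, it means among the compounds named here.

In a functional assay on MCF7 cells (Homo sapiens) for inhibition, read by CCK-8 assay (on this read-out lower numbers stand for stronger inhibition and higher numbers for weaker inhibition), three compounds built on one shared core have been measured. Compound 1, `Oc1ccccc1/C=N/c1nnc(SCc2nnc(-c3ccccc3Br)o2)s1`, gives 9140 nM; compound 2, `Oc1ccccc1/C=N/c1nnc(SCc2nnc(-c3ccc(Br)cc3)o2)s1`, gives 8320 nM; compound 3, `COc1ccc(-c2nnc(CSc3nnc(/N=C/c4ccccc4O)s3)o2)cc1`, gives 4560 nM. On these numbers compound 2 stands second highest of the three, nearest to compound 1 and furthest from compound 3, yet every gap lies within the scatter: a 1.1-fold lower number from compound 1 to compound 2 (0.04 log units; within the scatter), a 2.0-fold lower number from compound 1 to compound 3 (0.30 log units; within the scatter) and a 1.8-fold lower number from compound 2 to compound 3 (0.26 log units; within the scatter). Compound 4, `O=[N+]([O-])c1cccc(-c2nnc(CSc3nnc(/N=C/c4ccccc4O)s3)o2)c1`, has not yet been measured in this assay. It differs from compound 2 in one place: 3-nitrophenyl in place of 4-bromophenyl on an aromatic carbon. The three measured steps bear on this change, since each of them also exchanges the group on an aromatic carbon of the same core, and none of them moved the number beyond the scatter. For compound 4 the expected step is therefore a 1.2-fold lower number from compound 2 to compound 4 (0.08 log units; within the scatter), with no direction beyond the scatter. Compound 4 is estimated at 7000 nM, between 3000 nM and 16000 nM.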

Compound 4, half-maximal inhibitory concentration: 13900 nM
The estimate for compound 4 lay 2.0-fold (0.30 log units) below the measured number; the range from low to high includes it.
By their numbers in this assay, from the lowest: compounds 3, 2, 1 and 4 (each within the scatter of the next, the first and the last beyond it).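

In this assay the exchange of 4-methoxyphenyl for 3-nitrophenyl on this aromatic carbon of the shared core gives the only step beyond the scatter among these compounds, a modest one: a 3.0-fold higher number from compound 3 to compound 4 (0.48 log units; beyond the scatter). Measured against the two bromophenyl compounds, the same group stays within the scatter, with a 1.7-fold higher number from compound 2 to compound 4 (0.22 log units; within the scatter) and a 1.5-fold higher number from compound 1 to compound 4 (0.18 log units; within the scatter), so the exchanges at this place separate only compound 3 and compound 4. No evidence at hand bears on this step.

From the compounds shown here alone, what a 4-nitrophenyl or a 3-methoxyphenyl group would give here remains open, so the share of the group itself and the share of its position on the phenyl ring cannot be told apart. Also open, going by these compounds, is how an amine or a carboxylic acid on that phenyl ring would read in this assay.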